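This account rests on a few compounds, and the source may have more. Where it says the series, first, only, none or still open, it means among the compounds named here.

Working notes on the series. In an ADME assay on HEK-293T cells (Homo sapiens) for inhibition, read by CCK-8 assay, with a stated time of 48 h, tested at 20 uM (a lower number here means less inhibition of growth, a higher number more inhibition of growth at the concentration tested), compound 1 (`N#C/C(=C\c1ccccc1OS(=O)(=O)c1ccc(F)cc1)C(=O)Nc1nnc(Cc2ccc(F)cc2)s1`) is reported as "not toxic" (no number reported) without a number. Going by the values given here, compound 2 (`Cc1ccc(S(=O)(=O)Oc2ccccc2/C=C(\C#N)C(=O)Nc2nnc(Cc3cccc(F)c3)s2)cc1`) gives 9% as the only number available, so it has no rank against another value. Compound 3 (`N#C/C(=C\c1ccccc1OS(=O)(=O)c1ccc(F)cc1)C(=O)Nc1nnc(Cc2cccc(F)c2)s1`) departs from compound 2 by fluoro in place of methyl on an aromatic carbon as fluoro in place of methyl on an aromatic carbon, para to a large group. Among the compounds with values here, no measured step in this assay covers this change, so no shift beyond the scatter is expected in either direction. The expected change is a number 1 percentage points higher from compound 2 to compound 3 (within the scatter) and stays within the scatter. Compound 3 is estimated at 10% (range 2% to 22%).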

Compound 3, percent growth inhibition at one concentration: 17%
Estimate against measurement, compound 3: 7 percentage points below; low and high end bracket the measured number.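

In this assay, 4-methylphenyl to 4-fluorophenyl on the sulfonyl gives a number 8 percentage points higher from compound 2 to compound 3 (within the scatter). Going by these compounds alone, this is the first measured step at this place, para to a large group, and it shows that this exchange of methyl for fluoro leaves growth inhibition within the usual scatter. Nothing available bears on the reason for the size of this step. Open, on these data alone, is whether a methoxy group or an amine on this aromatic carbon would also stay within the scatter of compound 3 .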